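Amide series: arylamino replaces ethyl, compound 4 unmeasured

The source may report more compounds than this note shows. Statements on the series, on what has been measured and on what is new or still open speak of the compounds shown alone.

Compound 1 `CCCOc1ccc(C(=O)Nc2cccc(C)n2)cc1` gives 11100 nM in an in vitro assay on HEK-tsA201 cells for antagonist activity at Neuronal acetylcholine receptor; alpha3/beta4 (Homo sapiens), read by fluorescence and calcium flux; on this read-out lower numbers stand for stronger inhibition and higher numbers for weaker inhibition. Compound 2 `C=CCOc1ccc(C(=O)Nc2cccc(CC)n2)cc1` gives 27400 nM in this assay, and compound 3 `CCCOc1ccc(C(=O)Nc2cccc(CC)n2)cc1` gives 29200 nM in this assay. Compound 3 carries the highest of the three numbers: the step of a 1.1-fold higher number from compound 2 to compound 3 (0.03 log units; within the scatter) is within the scatter, whereas the step of a 2.6-fold higher number from compound 1 to compound 3 (0.42 log units; beyond the scatter) lies beyond it.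

Compound 4 `CCCOc1ccc(C(=O)Nc2cccc(Nc3ccccc3F)n2)cc1` differs from compound 3 by (2-fluorophenyl)amino in place of ethyl on an aromatic carbon. Of the measured steps only a 2.6-fold higher number from compound 1 to compound 3 (0.42 log units; beyond the scatter) bears on this change, since it also alters the group carried on that aromatic carbon; it was modest and went toward a higher number as methyl gave way to ethyl. The step of a 1.1-fold higher number from compound 2 to compound 3 (0.03 log units; within the scatter) concerns another part of the molecule and is within the scatter, so it offers no guide. Among the measured compounds shown here, the entering group is unlike anything measured, so the direction remains uncertain; the one comparable step points to a modest rise or to no change beyond the scatter. For compound 4 in this assay the expected value is 32000 nM, within 8000 nM to 110000 nM. This estimate corresponds to an expected step of a 1.1-fold higher number from compound 3 to compound 4 (0.04 log units; within the scatter).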

Compound 4, half-maximal inhibitory concentration: > 100000 nM
Compound 4 gave a limit, no number (the forecaster's own chance of this, stated with the estimate: 25%); middle value at least 3.1-fold (0.49 log units) from the limit.
By their numbers in this assay, from the lowest: compound 1; then compounds 2 and 3 (each within the scatter of the next). At a limit, above all of these: compound 4.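

In this assay compound 4 stands at a limit of the assay, not a number: the limit of > 100000 nM in this assay, at which 1 of the 4 values shown sits.

Among the compounds shown here, on the aromatic carbon next to the ring nitrogen, where the earlier compounds carried only methyl or ethyl, (2-fluorophenyl)amino gives an at least 3.4-fold higher number from compound 3 to compound 4 (0.53 log units; beyond the scatter) and an at least 9.0-fold higher number from compound 1 to compound 4 (0.95 log units; beyond the scatter). Across compounds 1, 3 and 4 the number rises as the group on this carbon grows, with no compound among these three against that order, though the full size of the last rise stays unknown at a limit.

The compounds shown do not separate the contributions of the fluorine, the phenyl ring and the amino nitrogen of the entering group. Going by these compounds, a plain phenylamino, a methylamino or a methoxy on this carbon would help to separate them, and it remains open whether any group here gives a lower number than compound 1 at 11100 nM.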